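The source may report more compounds than this note shows. Statements on the series, on what has been measured and on what is new or still open speak of the compounds shown alone.

Three ureas sharing one core have been measured in an ADME assay for permeability, using PAMPA, at pH 7.4; a higher number here means that the compound crosses the layer faster, a lower number that the compound crosses the layer more slowly. Compound 1 `COC(=O)c1ccc(NC(=O)Nc2cc(C)nc3ccccc23)cc1` gives 448 10^-6 cm/s, compound 2 `COC(=O)c1cccc(NC(=O)Nc2cc(C)nc3ccccc23)c1` gives 746 10^-6 cm/s, and compound 3 `Cc1cc(NC(=O)Nc2cccc(OC(F)(F)F)c2)c2ccccc2n1` gives 464 10^-6 cm/s. Compound 1 stands at the lowest of the three numbers, yet its gaps to compound 3 and to compound 2 both lie within the scatter. Compound 4 `Cc1cc(NC(=O)Nc2ccc(OC(F)(F)F)cc2)c2ccccc2n1` differs from compound 1 in one place: trifluoromethoxy in place of methoxycarbonyl on an aromatic carbon. The same exchange has been followed once already, at a different attachment point, where a 1.6-fold lower number from compound 2 to compound 3 (0.21 log units; within the scatter). Among the measured compounds shown here, only that one step bears on the question, and it points to no movement beyond the scatter. Compound 4 is therefore expected to give 400 10^-6 cm/s, with a range from 250 10^-6 cm/s to 650 10^-6 cm/s, meaning a 1.1-fold lower number from compound 1 to compound 4 (0.05 log units; within the scatter).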

Compound 4, apparent permeability: 531 10^-6 cm/s
For compound 4 the middle estimate is 1.3-fold (0.12 log units) below the measured one; the measured number falls inside the stated range.
By their numbers in this assay, from the lowest: compounds 1, 3, 4 and 2 (each within the scatter of the next).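

At the place para to a large group, trifluoromethoxy in place of methoxycarbonyl gives a 1.2-fold higher number from compound 1 to compound 4 (0.07 log units; within the scatter) in this assay. The exchange has now been followed at two attachment points, and neither step leaves the scatter. Nor can the attachment point be said to alter the outcome, since the two steps themselves do not separate: the same change on two cores in this assay, a 1.6-fold lower number (0.21 log units; within the scatter) from compound 2 to compound 3 and a 1.2-fold higher number (0.07 log units; within the scatter) from compound 1 to compound 4, 1.9-fold (0.28 log units) apart, within the scatter of two such steps.

The compounds shown leave open whether another group at this place, such as an amine or a carboxylic acid, moves the number beyond the scatter. On these data alone, whether the exchange stays as quiet away from the shared core also remains open.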